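This account rests on a few compounds, and the source may have more. Where it says the series, first, only, none or still open, it means among the compounds named here.

Values in a functional assay on cells (Platelet, Homo sapiens) for inhibition; on this read-out higher numbers stand for weaker inhibition and lower numbers for stronger inhibition:
- Compound 1 `CCOC(=O)c1ccc(-c2nn(-c3ccco3)c3ccccc23)cc1`: 340 nM
- Compound 2 `O=C(O)c1ccc(-c2nn(Cc3ccccc3)c3ccccc23)cc1`: > 10000 nM
- Compound 3 `COC(=O)c1ccc(-c2nn(Cc3ccccc3)c3ccccc23)cc1`: not yet measured

In this assay compound 2 gives > 10000 nM, which is a limit and not a number. This means there is no exact starting value for the step that follows.

Compound 3 differs from compound 2 in one place: methyl in place of hydrogen on an oxygen next to a carbonyl group. This is methyl in place of hydrogen on an oxygen next to a carbonyl group, so carboxy becomes methoxycarbonyl.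

Among the measured compounds shown here, no measured pair shows this change alone, so any expectation rests on indirect evidence. Compound 1 is also an ester and gives 340 nM, although it differs from compound 2 in other ways too. That single comparison suggests that the change should bring stronger inhibition in this assay, by a margin beyond the usual scatter. The expected step is an at least 12-fold lower number from compound 2 to compound 3 (1.09 log units; beyond the scatter), and its size remains uncertain. Compound 3 is estimated at 800 nM, with an expected range of 150 nM to 5000 nM.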

Compound 3, half-maximal inhibitory concentration: 560 nM
Compound 3: middle estimate off by 1.4-fold (0.15 log units), on the high side; measured number inside the range.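

In this assay, the pair shown here is the only one that differs in a single place, so it isolates methyl in place of hydrogen on an oxygen next to a carbonyl group. Turning carboxy into methoxycarbonyl gives an at least 17-fold lower number from compound 2 to compound 3 (1.25 log units; beyond the scatter), so this one added methyl is enough to bring a compound with no exact value into the measurable range. The value of compound 2, > 10000 nM, is a limit and not a number. The true size of the step remains open, because it starts from that limit: the limit of > 10000 nM in this assay, at which 1 of the 3 values shown sits.

Compound 1 differs from compound 3 in more than one place, and its value therefore cannot show how either change acts on its own. The compounds shown also leave open how inhibition would respond to an amide in place of the ester, or to a longer chain such as propyl on the same oxygen.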